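The source may report more compounds than this note shows. Statements on the series, on what has been measured and on what is new or still open speak of the compounds shown alone.

Of the compounds shown here, three built on one shared core have been tested in a functional assay on B16-F10 cells (Mus musculus) for inhibition, read by MTT assay, with a stated time of 72 h; on this read-out lower numbers stand for stronger inhibition and higher numbers for weaker inhibition. Compound 1 `COc1ccc(Nc2nc(SCc3cn(Cc4ccccc4Cl)nn3)nc(-c3ccccc3)c2C#N)cc1` gives 3990 nM. Compound 2 `Cc1ccc(Nc2nc(SCc3cn(Cc4ccccc4Cl)nn3)nc(-c3ccccc3)c2C#N)cc1` gives 3390 nM in this assay, and compound 3 `Cc1ccc(Nc2nc(SCc3cn(Cc4ccccc4Cl)nn3)nc(-c3ccc(C(C)C)cc3)c2C#N)cc1` gives 3530 nM. The step of a 1.2-fold lower number from compound 1 to compound 2 (0.07 log units; within the scatter) and the step of a 1.0-fold higher number from compound 2 to compound 3 (0.02 log units; within the scatter) both stay within the scatter, so none of the three can be called more or less active than another. Going by the values given here, on the numbers so far, compound 3 stands second highest of the three; the nearest to it is compound 2 and the furthest is compound 1, and both gaps lie within the scatter.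

Compound 4 `COc1ccc(Nc2nc(SCc3cn(Cc4ccccc4Cl)nn3)nc(-c3ccc(C(C)C)cc3)c2C#N)cc1` has not yet been measured. It differs from compound 3 by methoxy in place of methyl on an aromatic carbon. Among the compounds with values here, this is the same exchange, run backwards, as the one between compound 1 and compound 2, where a 1.2-fold lower number from compound 1 to compound 2 (0.07 log units; within the scatter) stayed within the scatter. Reading that step in reverse, compound 4 is expected to show a 1.2-fold higher number from compound 3 to compound 4 (0.07 log units; within the scatter), a step no larger than the scatter itself. For compound 4 the estimate in this assay is 4100 nM, with a range from 2000 nM to 8400 nM.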

Compound 4, half-maximal inhibitory concentration: 2690 nM
The estimate for compound 4 lay 1.5-fold (0.18 log units) above the measured number, and the stated range covers the measured number.
By their numbers in this assay, from the lowest: compounds 4, 2, 3 and 1 (each within the scatter of the next).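

In this assay, the exchange of 4-methylphenyl for 4-methoxyphenyl now gives a 1.3-fold lower number from compound 3 to compound 4 (0.12 log units; within the scatter), so it has been read with the isopropyl group present as well as absent, and the two readings cannot be told apart: the same change on two cores in this assay, a 1.2-fold lower number (0.07 log units; within the scatter) from compound 1 to compound 2 and a 1.3-fold higher number (0.12 log units; within the scatter) from compound 4 to compound 3, 1.5-fold (0.19 log units) apart, within the scatter of two such steps. The isopropyl change, read with methoxy in place, gives a 1.5-fold lower number from compound 1 to compound 4 (0.17 log units; within the scatter), and it too agrees with its earlier reading: the same change on two cores in this assay, a 1.0-fold higher number (0.02 log units; within the scatter) from compound 2 to compound 3 and a 1.5-fold lower number (0.17 log units; within the scatter) from compound 1 to compound 4, 1.5-fold (0.19 log units) apart, within the scatter of two such steps. Across compounds 1, 2, 3 and 4, neither change moves the number beyond the scatter, whether or not the other change is present.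

As far as these compounds go, it remains open whether a different group in the place of methyl or methoxy, such as an amine, a carboxylic acid or a longer chain, would shift the number beyond the scatter. The same question stands for the place that carries the isopropyl group.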